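Methyl in place of hydrogen, repeated on compound 3

The source may hold more compounds than are shown below. What is called first, only, known or untested is meant among the compounds shown, and "the series" means these compounds.

Four compounds share one core. Compound 1 `O=C(/C=C/c1ccccc1)Nc1nnc(-c2ccccc2)s1` gives 1.47 ug/mL in a functional assay on MCF7 cells (Homo sapiens) for antiproliferative activity, read by MTT assay, with a stated time of 48 h; a lower number here means a stronger inhibitor, a higher number a weaker inhibitor. Compound 2 `Cc1ccc(/C=C/C(=O)Nc2nnc(-c3ccccc3)s2)cc1` differs from compound 1 by methyl in place of hydrogen on an aromatic carbon; in this assay compound 2 gives 1.23 ug/mL; the step of a 1.2-fold lower number from compound 1 to compound 2 (0.08 log units; within the scatter). Compound 3 `O=C(/C=C/c1ccccc1)Nc1nnc(-c2ccc(Br)cc2)s1` carries a different core, set apart from compound 1 by bromo in place of hydrogen on an aromatic carbon; in this assay compound 3 gives 1.5 ug/mL; the step of a 1.0-fold higher number from compound 1 to compound 3 (0.01 log units; within the scatter). The values of compound 2 and compound 3 lie within the scatter of one another, so no order among the three can be read.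

Compound 4 `Cc1ccc(/C=C/C(=O)Nc2nnc(-c3ccc(Br)cc3)s2)cc1` is not yet measured. It differs from compound 3 by methyl in place of hydrogen on an aromatic carbon, the same change as that from compound 1 to compound 2, made on the core of compound 3 rather than on the core of compound 1. For the measured compounds named here, with only one earlier instance, and that one within the scatter, the expectation is that the step is small: a 1.2-fold lower number from compound 3 to compound 4 (0.08 log units; within the scatter) is estimated for compound 4, resting on a 1.2-fold lower number from compound 1 to compound 2 (0.08 log units; within the scatter). Compound 4 is thus expected to give 1.25 ug/mL, with a range from 0.7 ug/mL to 2.3 ug/mL.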

Compound 4, half-maximal inhibitory concentration: 1.32 ug/mL
Compound 4: middle estimate off by 1.1-fold (0.02 log units), on the low side; the measured number falls inside the stated range.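

In this assay, methyl in place of hydrogen on the core of compound 3 gives a 1.1-fold lower number from compound 3 to compound 4 (0.06 log units; within the scatter) and matches the same change on the core of compound 1: the same change on two cores in this assay, a 1.2-fold lower number (0.08 log units; within the scatter) from compound 1 to compound 2 and a 1.1-fold lower number (0.06 log units; within the scatter) from compound 3 to compound 4, 1.1-fold (0.02 log units) apart, within the scatter of two such steps. Bromo in place of hydrogen, read on the core of compound 2, gives a 1.1-fold higher number from compound 2 to compound 4 (0.03 log units; within the scatter) and matches in the same way: the same change on two cores in this assay, a 1.0-fold higher number (0.01 log units; within the scatter) from compound 1 to compound 3 and a 1.1-fold higher number (0.03 log units; within the scatter) from compound 2 to compound 4, 1.1-fold (0.02 log units) apart, within the scatter of two such steps. For the compounds shown here, both changes therefore carry from one core to the other without a visible difference across these four compounds, but every step lies within the scatter, so the agreement shows only that neither change moves the number measurably here, and it establishes neither a real effect of either group nor a rule beyond these cores.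

The compounds shown leave open whether any other group in the same place, such as an amine, a carboxylic acid or a longer chain, would give a step beyond the scatter. They also leave open whether such a step, if found, would carry from one core to another.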